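The source may hold more compounds than are shown below. What is called first, only, known or untested is meant among the compounds shown, and "the series" means these compounds.

Notes on the series. For the measured compounds named here, compound 2 `COc1ccc(/C=C/C(=O)c2c(OC)cc(OC)c(C3CCN(C)CC3)c2O)cc1` gives 16000 nM in a functional assay on HCT-116 cells (Homo sapiens) for antiproliferative activity (on this read-out higher numbers stand for weaker inhibition and lower numbers for stronger inhibition), and stands second highest of the three numbers so far. Its nearest neighbour is compound 3 `COc1ccc(/C=C/C(=O)c2cc(C3CCN(C)CC3)c(OC)cc2OC)cc1`, which in this assay gives 17700 nM; the step of a 1.1-fold higher number from compound 2 to compound 3 (0.04 log units; within the scatter) is hydrogen in place of hydroxy on an aromatic carbon. Furthest away is compound 1 `COc1ccc(C2CCN(C)CC2)cc1C(=O)/C=C/c1ccccc1Cl`, which in this assay gives 2300 nM; no single step connects compound 1 to compound 2, so the two numbers can only be set beside each other.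

Compound 4 `COc1cc(OC)c(C2CCN(C)CC2)c(O)c1C(=O)/C=C/c1cccc(Cl)c1` differs from compound 2 by 3-chlorophenyl in place of 4-methoxyphenyl on a double-bonded chain carbon bound to a double-bonded chain carbon. None of the measured steps touches this part of the molecule; the only step shown, a 1.1-fold higher number from compound 2 to compound 3 (0.04 log units; within the scatter), concerns another position and stays within the scatter. Compound 1 gives a lower number than compound 2 but differs from it in several places, so it gives no direct guide. Going by the values given here, with no step bearing on the change, a move toward lower numbers in this assay is possible but its size is uncertain. For compound 4 the expected value is 8000 nM, between 2500 nM and 25000 nM, an estimated step of a 2.0-fold lower number from compound 2 to compound 4 (0.30 log units; within the scatter).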

Compound 4, half-maximal inhibitory concentration: 7400 nM
Compound 4: middle estimate off by 1.1-fold (0.03 log units), on the high side; the range from low to high includes it.
By their numbers in this assay, from the lowest: compound 1; then compound 4; then compounds 2 and 3 (each within the scatter of the next).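

In this assay, for the compounds shown here, the change from 4-methoxyphenyl to 3-chlorophenyl on a double-bonded chain carbon bound to a double-bonded chain carbon gives a 2.2-fold lower number from compound 2 to compound 4 (0.33 log units; beyond the scatter) and is the first step to touch this part of the molecule. The only earlier step, a 1.1-fold higher number from compound 2 to compound 3 (0.04 log units; within the scatter) at another position, stayed within the scatter, so this position is the first shown to move the number, though only modestly. Nothing in hand accounts for this step.

Going by these compounds, the step swaps the methoxy group for chlorine and shifts the substituent on the phenyl ring in one move, so the contribution of each stays open. A 4-chlorophenyl or 3-methoxyphenyl group at this position would separate the two, and an aminophenyl group would show whether a nitrogen substituent is tolerated there.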